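A few compounds are considered here, and "the series" means these few. Any claim that something is new, unique, unknown or untested is made for them only; others in the source may bear on it.

Measured compounds in an assay on HEK-293T cells for inhibition of diacylglycerol lipase-alpha (Homo sapiens), read by colorimetric assay; a lower number here means a stronger inhibitor, a higher number a weaker inhibitor:
Compound 1, `O=C(CCCCCCc1ccccc1)c1nncs1`: in this assay compound 1 shows only a limit, > 10000 nM.
Compound 2, `O=C(CCCCCCc1ccccc1)c1nnn[nH]1`: in this assay compound 2 likewise shows only a limit, > 10000 nM; > 10000 nM (2 entries).
Compound 3, `O=Cc1coc(C(=O)CCCCCCc2ccccc2)n1`: in this assay compound 3 gives 1510 nM.

For the measured compounds named here, compound 3 therefore holds the only number in this assay; the entries for compound 1 and compound 2 are limits, one of them being (the limit of > 10000 nM in this assay, at which 1 of the 3 values shown sits). Going by the values given here, the single measured step is an at least 6.6-fold lower number from compound 1 to compound 3 (0.82 log units; beyond the scatter), a swap of the ring on the carbonyl carbon, at least modest in size.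

Compound 4, `CNC(=O)c1coc(C(=O)CCCCCCc2ccccc2)n1`, remains to be measured in this assay. It differs from compound 3 by methylamino in place of hydrogen on a carbonyl carbon. Among the compounds with values here, no measured step touches this carbonyl position; the step of an at least 6.6-fold lower number from compound 1 to compound 3 (0.82 log units; beyond the scatter) concerns the ring and gives no direct guide to the formyl-to-methylcarbamoyl change. With nothing pointing firmly in either direction, for compound 4 the expected step is a 1.7-fold higher number from compound 3 to compound 4 (0.22 log units; within the scatter), small and if anything toward weaker inhibition. Compound 4 is estimated at 2500 nM, within 800 nM to 10000 nM.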

Compound 4, half-maximal inhibitory concentration: > 10000 nM
Compound 4 ended at the assay's limit; the forecaster's own chance of this, stated with the estimate: 25%; at least 4.0-fold (0.60 log units) between middle value and limit.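

For the compounds shown here, the earlier compounds varied only the ring on the chain's carbonyl carbon; this result is the first reading at the second carbonyl carbon, and in this assay that position is not indifferent. Formyl to methylcarbamoyl gives an at least 6.6-fold higher number from compound 3 to compound 4 (0.82 log units; beyond the scatter), so measurable inhibition is not kept once methylamino replaces hydrogen on this carbonyl carbon. Compound 4 shows only a limit, > 10000 nM, so the full size of the step stays unknown, and the series now reads: the limit of > 10000 nM in this assay, at which 2 of the 4 values shown sit.

Only formyl and methylcarbamoyl are shown on this carbonyl carbon, so it stays open whether the step belongs to methylcarbamoyl alone or to any replacement of formyl; a primary amide, a carboxylic acid or a methyl ester there would bear on that. Also open is whether a longer chain would shift these readings, since the chain is the same in all compounds shown.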